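The source may hold more compounds than are shown below. What is called first, only, known or untested is meant among the compounds shown, and "the series" means these compounds.

In a functional assay on DU-145 cells (Homo sapiens) for inhibition, read by trypan blue exclusion, with a stated time of 96 h (on this read-out higher numbers stand for weaker inhibition of growth and lower numbers for stronger inhibition of growth), compound 1 (`O=C(/C(=C\c1ccc(O)c([N+](=O)[O-])c1)SCc1ccc(Br)cc1)c1c(F)c(F)c(F)c(F)c1F`) gives 10000 nM and compound 2 (`O=C(/C(=C\c1ccc(O)c([N+](=O)[O-])c1)SCc1ccc(Br)cc1)c1ccc(Cl)cc1Cl`) gives 10000 nM. Among the compounds with values here, these two stand level, and they share the highest number of the three measured so far. Compound 3 (`Cc1ccc(CS/C(=C/c2ccc(F)c([N+](=O)[O-])c2)C(=O)c2ccc(Cl)c([N+](=O)[O-])c2)cc1`) gives 1000 nM, a clearly lower number that means stronger inhibition of growth, but it differs from compound 2 in several places, so it says little about any single change.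

Compound 4 (`O=C(/C(=C\c1ccc(O)c([N+](=O)[O-])c1)SCc1ccc(Br)cc1)c1ccc(O)cc1O`) alters one group of compound 2: 2,4-dihydroxyphenyl in place of 2,4-dichlorophenyl on a carbonyl carbon. In words, this is 2,4-dihydroxyphenyl in place of 2,4-dichlorophenyl on a carbonyl carbon. Within the data shown here, the only measured step at that place, 2,4-dichlorophenyl in place of 2,3,4,5,6-pentafluorophenyl, shows no change at the digits printed from compound 1 to compound 2 (within the scatter). Among the measured compounds shown here, that step brought in no hydroxy groups, so it is only a loose guide, and no measurement yet tests them here. No step beyond the scatter is therefore expected, with a slight lean towards a lower number. The expected change is a 1.7-fold lower number from compound 2 to compound 4 (0.22 log units; within the scatter). For compound 4 the estimated value is 6000 nM, with an expected range from 1500 nM to 20000 nM.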

Compound 4, concentration for 50% growth inhibition: > 100000 nM
Compound 4: a limit, no number (the forecaster's own chance of this, stated with the estimate: 10%); at least 16-fold (1.22 log units) between middle value and limit.
By their numbers in this assay, from the lowest: compound 3; then compounds 1 and 2 (each within the scatter of the next). At a limit, above all of these: compound 4.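

Compound 4 stands at a limit of the assay and not at a number: the limit of > 100000 nM in this assay, at which 1 of the 4 values shown sits.

In this assay, 2,4-dihydroxyphenyl in place of 2,4-dichlorophenyl on the carbonyl carbon gives an at least 10-fold higher number from compound 2 to compound 4 (1.00 log units; beyond the scatter), and in place of 2,3,4,5,6-pentafluorophenyl it gives an at least 10-fold higher number from compound 1 to compound 4 (1.00 log units; beyond the scatter). Within the data shown here, the earlier step at this place showed no change at the digits printed from compound 1 to compound 2 (within the scatter), so these are the first steps here to lie beyond the scatter, and they show that growth inhibition at this place depends on which ring is attached.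

The compounds shown leave open whether a single hydroxy group on this ring would weaken inhibition of growth as much as two do. They also leave open what a methoxy group or an amine on the same ring would give.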